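This account rests on a few compounds, and the source may have more. Where it says the series, first, only, none or still open, it means among the compounds named here.

Measured so far:
compound 1, `O=C(CSc1nnnn1-c1ccccc1)N/N=c1/scc(-c2ccc(Cl)cc2)n1-c1ccccc1` — 62.3%
compound 2, `O=C(CSc1ncccn1)N/N=c1/scc(-c2ccc(Br)cc2)n1-c1ccccc1` — 72.3%

In a functional assay on C6 cells (Rattus norvegicus) for cytotoxicity, read by MTT assay, with a stated time of 24 h, tested at 25 ug/mL (on this read-out lower numbers stand for a stronger effect and higher numbers for a weaker effect at the one concentration tested), compound 2 gives 72.3%, the highest of the two numbers. The nearest number is that of compound 1, which in this assay gives 62.3%; the gap between them lies within the scatter, so the two compounds cannot be ordered on these numbers.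

Compound 3, `O=C(CSc1ncccn1)N/N=c1/scc(-c2ccc(Cl)cc2)n1-c1ccccc1`, is still to be measured. Its difference from compound 2 is chloro in place of bromo on an aromatic carbon. Going by the values given here, no pair of measured compounds differs in this one place alone: compound 1 carries chloro at the same place but also differs from compound 2 in the group attached to the sulfur, so the two values of compound 1 and compound 2 show only that both compounds fall in the same band.

The change is one halogen for another of similar kind on the same aromatic carbon. In this assay a step of a number 4.3 percentage points lower from compound 2 to compound 3 (within the scatter) is expected, which is no more than the scatter of repeated measurements. Compound 3 is therefore estimated at 68%, with a range from 54% to 82%.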

Compound 3, a percentage reported as activity, at one concentration (the size of the read-out at that concentration, not a potency): 91.1%
Compound 3: the middle estimate sits 23.1 percentage points below what was measured; measured number outside the range, above it.
By their numbers in this assay, from the lowest: compounds 1 and 2 (each within the scatter of the next); then compound 3.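

In this assay, chloro in place of bromo on the aromatic carbon brings a number 18.8 percentage points higher from compound 2 to compound 3 (beyond the scatter), so in the pair carrying pyrimidin-2-yl on the sulfur this halogen exchange is not a neutral swap, and the change runs towards a weaker effect at the one concentration tested. With 4-chlorophenyl held constant, pyrimidin-2-yl in place of 1-phenyl-1H-tetrazol-5-yl on the sulfur brings a number 28.8 percentage points higher from compound 1 to compound 3 (beyond the scatter), which shows that the group on the sulfur also shifts the read-out and leaves compound 3 as the weakest of the three compounds shown. The information at hand offers no measured basis for explaining either step.

Going by these compounds alone, whether the halogen step carries over to compounds with 1-phenyl-1H-tetrazol-5-yl on the sulfur remains open, since the exchange is seen only in the pair of compound 2 and compound 3. Also open, on these data alone, is how fluoro, methoxy or an amine at the same place on the aromatic ring would read in this assay, and whether the two halogens mark a trend or only an isolated difference.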